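This account rests on a few compounds, and the source may have more. Where it says the series, first, only, none or still open, it means among the compounds named here.

Working notes on the series.

Compound 1 `ClCc1ccc(Cn2cnc3c(Cl)ncnc32)cc1` and compound 3 `ClCc1ccc(Cn2cnc3c(Cl)nc(Cl)nc32)cc1` share one core; compound 2 `ClCc1ccccc1Cn1cnc2ncnc(Cl)c21` and compound 4 `ClCc1ccccc1Cn1cnc2nc(Cl)nc(Cl)c21` share a second one, and compound 2 is built from the same atoms as compound 1 joined differently. The difference between the two cores is not broken down here.

In a functional assay on HOP-62 cells (Homo sapiens) for cytotoxicity, read by sulforhodamine B assay, with a stated time of 48 h (on this read-out higher numbers stand for weaker inhibition of growth and lower numbers for stronger inhibition of growth), compound 1 gives 6760 nM and compound 3 gives 5130 nM. In this assay compound 2 gives 28800 nM, the highest number of the three measured compounds and apart from both others by more than the usual scatter. Compound 4 has not yet been measured in this assay.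

The change from compound 1 to compound 3 is chloro in place of hydrogen on an aromatic carbon. It gave a 1.3-fold lower number from compound 1 to compound 3 (0.12 log units; within the scatter). The change from compound 2 to compound 4 is chloro in place of hydrogen on an aromatic carbon, the same change made on the other core; the surroundings of the place are described in identical terms for both pairs.

Among the measured compounds shown here, only one prior instance of this change exists, and it stayed within the scatter, so nothing argues for a large shift on the second core. For the measured compounds named here, the step from compound 2 to compound 4 is expected to be a 1.3-fold lower number from compound 2 to compound 4 (0.12 log units; within the scatter), resting solely on the single earlier step of a 1.3-fold lower number from compound 1 to compound 3 (0.12 log units; within the scatter). Compound 4 is therefore estimated at 22000 nM in this assay. The estimate for compound 4 is expected to fall between 10000 nM and 50000 nM.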

Compound 4, concentration for total growth inhibition: 5490 nM
Compound 4: the middle estimate sits 4.0-fold (0.60 log units) above what was measured; measured number below the stated range.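

On the core of compound 2, chloro in place of hydrogen on an aromatic carbon, at the place between two ring nitrogen atoms, gave a 5.2-fold lower number from compound 2 to compound 4 (0.72 log units; beyond the scatter) in this assay. The effect of this change therefore did not carry over in size from one core to the other, and a step read on one core is a poor guide to the same step on the other: the same change on two cores in this assay, a 1.3-fold lower number (0.12 log units; within the scatter) from compound 1 to compound 3 and a 5.2-fold lower number (0.72 log units; beyond the scatter) from compound 2 to compound 4, 4.0-fold (0.60 log units) apart, beyond the scatter of two such steps

This rests on two pairs in a single assay, so it shows that the result of the change depends on the core in these compounds, but it does not show which feature of the cores is responsible, nor whether the gap would hold in other cells or on further cores.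

The compounds shown carry only hydrogen or chloro at this place, so it remains open how an amine, a methoxy group or a longer chain there would behave on each core. On these data alone, it also remains open whether such groups would separate the two cores as chloro does, or whether the gap belongs to chloro alone.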